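Notes toward compound 4

The compounds below may be only part of what the source reports. "The series", "measured", "known", "first", "only" and "open" are said of these compounds alone.

Measured so far:
compound 1 `O=C(Nc1ccc(C(F)(F)F)nc1)c1csc(Cc2c(Cl)cccc2Cl)n1`: 130 nM
compound 2 `O=C(Nc1ccccc1Br)c1csc(Cc2c(Cl)cccc2Cl)n1`: > 4000 nM (a limit)
compound 3 `O=C(Nc1ccc(C(F)(F)F)cc1)c1csc(-c2c(Cl)cccc2Cl)n1`: > 4000 nM (a limit)

In an assay on CHO cells, read by calcium flux (on this read-out higher numbers stand for weaker inhibition and lower numbers for stronger inhibition), compound 1 gives 130 nM. Compound 2 reaches only the limit > 4000 nM in this assay. For the measured compounds named here, compound 3 likewise stands at the limit > 4000 nM in this assay, so its true value is unknown and no measured step touches it. Two of the three values rest at the limit of > 4000 nM in this assay, at which 2 of the 3 values shown sit. Compound 4 `O=C(Nc1ccc(C(F)(F)F)cc1)c1csc(Nc2ccccc2Cl)n1` is not yet measured and differs from compound 3 by (2-chlorophenyl)amino in place of 2,6-dichlorophenyl on an aromatic carbon. Going by the values given here, with no measured step of this kind, the expectation is loose: a downward step toward stronger inhibition in this assay, of moderate size, because compound 1 shows the series can reach 130 nM. Compound 4 is estimated at 1000 nM, within 150 nM to 4000 nM, an expected step of an at least 4.0-fold lower number from compound 3 to compound 4 (0.60 log units; beyond the scatter).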

Compound 4, half-maximal inhibitory concentration: 1410 nM
Estimate against measurement, compound 4: 1.4-fold (0.15 log units) below, and the stated range covers the measured number.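

In this assay, this position responds to the change: (2-chlorophenyl)amino in place of 2,6-dichlorophenyl gives an at least 2.8-fold lower number from compound 3 to compound 4 (0.45 log units; beyond the scatter). For the compounds shown here, compound 4 thus gives the first number for a compound carrying a group at this position without a carbon-only attachment to the ring. Compound 3 stands at a limit, so the step is only a bound: the limit of > 4000 nM in this assay, at which 2 of the 4 values shown sit.

The step joins two changes, the amino link and the loss of one chlorine, and the compounds shown do not separate them. From the compounds shown here alone, how (2,6-dichlorophenyl)amino or a phenyl group joined through an ether oxygen would read at this position remains open.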